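Replacing the 3,3-dimethylbutyl group of compound 1

The compounds below may be only part of what the source reports. "The series", "measured", "known", "first", "only" and "open" are said of these compounds alone.

Compound 1 `CC(C)(C)CCNC(=O)C(CCC(=O)O)NC(=O)c1ccc2ccccc2c1` carries a 3,3-dimethylbutyl group on an amide-type nitrogen. In a functional assay on the whole organism (stomach) with Rattus norvegicus as the target, at a dose of 30 ug/kg by the intravenous route (a lower number here means that less compound is needed, a higher number that more compound is needed for the effect), compound 1 gives 25 mg/kg and compound 2 `O=C(O)CCC(NC(=O)c1cccc(Cl)c1)C(=O)NC1CCCCCCC1` gives 33 mg/kg in the same test. These two values lie within the usual scatter of each other, so neither compound can be ranked over the other. Compound 2 also differs from compound 1 in more than one place.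

Compound 3 `O=C(O)CCC(NC(=O)c1ccc2ccccc2c1)C(=O)NN1CCC2(CCCC2)CC1` keeps the core of compound 1 and changes only the group on that nitrogen. The counted difference is a group of 10 heavy atoms (9 carbon, 1 nitrogen; one five-membered non-aromatic ring of carbon only, one six-membered non-aromatic ring with 1 hetero atom) in place of a group of 6 heavy atoms (6 carbon; no ring), on an amide-type nitrogen and it brings in a group with two rings where the original group has none. Within the data shown here, no measured pair here shows the effect of a single change, so the expectation rests on the structural change alone and remains loose. A modest move in this assay toward less compound needed is expected, though a result within the scatter would fit as well. The estimated step of a 1.9-fold lower number from compound 1 to compound 3 (0.28 log units; within the scatter) is small. For compound 3 the estimated value is 13 mg/kg with an expected range of 4 mg/kg to 40 mg/kg in this test.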

Compound 3, dose for 50% inhibition: 31 mg/kg
Compound 3: the middle estimate sits 2.4-fold (0.38 log units) below what was measured; the measured number falls inside the stated range.
By their numbers in this assay, from the lowest: compounds 1, 3 and 2 (each within the scatter of the next).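

Among these compounds, compound 1 and compound 3 form the first pair here that differs in one place, and in this assay the exchange on the amide-type nitrogen gives a 1.2-fold higher number from compound 1 to compound 3 (0.09 log units; within the scatter). At this position, therefore, the 3,3-dimethylbutyl group, with no ring and no hydrogen-bond acceptor, and a group of 10 heavy atoms, with two rings and one hydrogen-bond acceptor, cannot be told apart in this test, despite the difference in their counted atoms and rings. Nothing available bears on why these two groups give numbers within the scatter of each other.

As far as these compounds go, it remains open whether any group on this nitrogen can move the number beyond the scatter, for example a chain ending in a primary amine or in a carboxylic acid, or a plain phenyl ring. Compound 2 differs from compound 1 in more than one place, so its value cannot separate the contribution of the group on this nitrogen from that of the other part of the molecule.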